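Aryl groups in place of methyl on the shared core

The source may report more compounds than this note shows. Statements on the series, on what has been measured and on what is new or still open speak of the compounds shown alone.

In a functional assay, with a stated time of 90 s (a lower number here means a stronger inhibitor, a higher number a weaker inhibitor), the measured compounds stand as follows:
compound 1 `Cc1nc2c3ccccc3ccc2c2nc3c(ccc4ccccc43)c(C)c12`: 195 ug/mL
compound 2 `Cc1nc2c3ccccc3ccc2c2nc3c(ccc4ccccc43)c(-c3nccnc3N)c12`: 134 ug/mL
compound 3 `Cc1nc2c3ccccc3ccc2c2nc3c(ccc4ccccc43)c(-c3cccc4ccccc34)c12`: 179 ug/mL

Compound 1 carries the highest number of the three, but the spread is small: the nearest is compound 3, with a 1.1-fold lower number from compound 1 to compound 3 (0.04 log units; within the scatter), and the furthest is compound 2, with a 1.5-fold lower number from compound 1 to compound 2 (0.16 log units; within the scatter). Both steps replace the methyl on the same aromatic carbon with an aryl group and neither moves the number beyond the scatter. The step between the two aryl compounds, a 1.3-fold higher number from compound 2 to compound 3 (0.13 log units; within the scatter), is likewise within the scatter.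

Compound 4 `Cc1nc2c3ccccc3ccc2c2nc3c(ccc4ccccc43)c(-c3cc(O)nc4ccccc34)c12` follows the same pattern of change from compound 1: 2-hydroxyquinolin-4-yl in place of methyl on an aromatic carbon. The two comparable steps, from compound 1 to compound 2 and from compound 1 to compound 3, both gave numbers a little lower than compound 1 without leaving the scatter, so a step of similar size, downward or none, is expected here in this assay. Within the data shown here, nothing among the measured compounds points to a larger move in either direction. The estimate for compound 4 is therefore 150 ug/mL, expected between 80 ug/mL and 280 ug/mL, corresponding to an expected 1.3-fold lower number from compound 1 to compound 4 (0.11 log units; within the scatter).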

Compound 4, half-maximal inhibitory concentration: 148 ug/mL
Estimate against measurement, compound 4: 1.0-fold (0.01 log units) above; the range from low to high includes it.
By their numbers in this assay, from the lowest: compounds 2, 4, 3 and 1 (each within the scatter of the next).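

In this assay, the aromatic carbon opposite the ring nitrogen also accepts 2-hydroxyquinolin-4-yl in place of methyl without leaving the scatter, with a 1.3-fold lower number from compound 1 to compound 4 (0.12 log units; within the scatter). Among the aryl groups, the new group is not separated from naphthalen-1-yl, with a 1.2-fold lower number from compound 3 to compound 4 (0.08 log units; within the scatter), or from 3-aminopyrazin-2-yl, with a 1.1-fold higher number from compound 2 to compound 4 (0.04 log units; within the scatter). Among these compounds, three aryl groups that differ in ring count and in hetero atoms therefore give numbers that cannot be told apart at this position, so the series so far shows no response to the identity of the aryl group.

Open, on these data alone, is whether a carboxylic acid, a simple amine or a longer alkyl chain on this carbon would move the number beyond the scatter. No supporting measurement bears on this result.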